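This account rests on a few compounds, and the source may have more. Where it says the series, first, only, none or still open, it means among the compounds named here.

Compound 1 `CC1(C)N=C(N)N=C(N)N1c1ccccc1N` gives 4.11 in an assay for inhibition of Dihydrofolate reductase (Bos taurus), at pH 6.25; a higher number here means a more potent compound, by a factor of ten per unit of this negative logarithm, a lower number a less potent compound. For the measured compounds named here, compound 2 `CSc1ccccc1N1C(N)=NC(N)=NC1(C)C` gives 3.54 in this assay, the lower of the two numbers known so far, set apart by a number 0.57 log units lower from compound 1 to compound 2 (beyond the scatter). Compound 3 `CC1(C)N=C(N)N=C(N)N1c1ccccc1S` differs from compound 2 by hydrogen in place of methyl on a sulfur. Going by the values given here, no measured step covers this change directly; the one known step concerns the whole aromatic substituent and is of modest size, so only a small movement is anticipated here. Compound 3 is expected to give about 3.7, within a range of 3.2 to 4.2. This amounts to an expected a number 0.16 log units higher from compound 2 to compound 3 (within the scatter).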

Compound 3, logarithm of the reciprocal of the active concentration, log(1/C): 7.2
For compound 3 the middle estimate is 3.50 log units below the measured one; the whole stated range lies below it.
By their numbers in this assay, from the lowest: compound 2; then compound 1; then compound 3.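

In this assay the group on this aromatic carbon turns out to matter far more than the earlier modest step suggested. Hydrogen in place of methyl on the sulfur brings a number 3.66 log units higher from compound 2 to compound 3 (beyond the scatter) and so a single methyl separates the lowest number from the highest. Sulfanyl in place of amino brings a number 3.09 log units higher from compound 1 to compound 3 (beyond the scatter) and thus also surpasses the amino compound. Nothing available here explains the size of these steps. Still open, as far as these compounds go, is how a hydroxyl or an ethylsulfanyl at this place would compare with sulfanyl.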